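Moving the Furan Attachment Point on a Dihydropyrimidinone Core

The source may report more compounds than this note shows. Statements on the series, on what has been measured and on what is new or still open speak of the compounds shown alone.

Two compounds with numbers in hand share a six-membered non-aromatic ring with two nitrogens. Compound 1 `CCCOC(=O)C1=C(C)NC(=O)NC1c1ccoc1` carries a propyl ester and a furan-3-yl group on that core. In an assay on membranes from HEK293 cells for displacement of a labelled ligand from adenosine receptor A2b (Homo sapiens), read by scintillation counting, with a stated time of 30 min (on this read-out higher numbers stand for weaker inhibition and lower numbers for stronger inhibition), compound 1 gives 1190 nM. Compound 2 `CC1=C(c2ncc(C)o2)C(c2ccco2)NC(=O)N1` carries instead a 5-methyl-1,3-oxazol-2-yl group and a furan-2-yl group. In this assay compound 2 gives 905 nM. The two values sit within the usual scatter of each other, so the numbers alone do not separate compound 2 from compound 1.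

Compound 3 `CC1=C(c2ncc(C)o2)C(c2ccoc2)NC(=O)N1` has not yet been measured. It differs from compound 2 in one place: furan-3-yl in place of furan-2-yl on a saturated ring carbon. Compound 1 already shows that a furan-3-yl group on this core is compatible with a number in the same region, though its other substituent also differs, so the comparison is only loose. Among the measured compounds shown here, no measured pair isolates this change, and no step beyond the scatter is expected in this assay. Compound 3 is estimated at 1200 nM, with a plausible range from 400 nM to 3600 nM, which means an expected step of a 1.3-fold higher number from compound 2 to compound 3 (0.12 log units; within the scatter).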

Compound 3, inhibition constant: 801 nM
Compound 3: middle estimate off by 1.5-fold (0.18 log units), on the high side, and the stated range covers the measured number.
By their numbers in this assay, from the lowest: compounds 3, 2 and 1 (each within the scatter of the next).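

Furan-3-yl in place of furan-2-yl on the saturated ring carbon gives in this assay a 1.1-fold lower number from compound 2 to compound 3 (0.05 log units; within the scatter) and stays within the scatter, so this first pair differing only in the furan attachment does not separate the two furan groups at this place. With furan-3-yl held the same, 5-methyl-1,3-oxazol-2-yl in place of propoxycarbonyl on the double-bonded ring carbon gives a 1.5-fold lower number from compound 1 to compound 3 (0.17 log units; within the scatter) and also stays within the scatter, so these numbers do not separate the ester from the oxazole either. Nothing beyond the binding numbers is available to explain either result.

Neither step goes beyond the scatter, so the compounds shown do not reveal which changes at these two places would move the number in a way that can be read. Open questions include whether a phenyl ring or a longer chain on the saturated ring carbon, or a carboxylic acid or an amide on the double-bonded ring carbon, would give a clearly different number in this assay on the shared core.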